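Removing an acetamido tail from a trithiocarbonate ketone

The source may report more compounds than this note shows. Statements on the series, on what has been measured and on what is new or still open speak of the compounds shown alone.

Measured compounds:
compound 1, `CCSC(=S)OCC(=O)c1ccc(OC)cc1`, 2990 nM
compound 2, `CCOC(=S)SCC(=O)c1ccc(OC)cc1`, 4640 nM
compound 3, `COc1ccc(C(=O)CSC(=S)SCCNC(C)=O)cc1`, 11100 nM

All three were tested in a functional assay on HeLa cells (Homo sapiens) for cytotoxicity, read by resazurin assay, with a stated time of 72 h; a lower number here means a stronger inhibitor, a higher number a weaker inhibitor. Compound 3 gives the highest number of the three, with compound 2 as its nearest neighbour at a lower number and compound 1 furthest, also lower. Among the compounds with values here, the only single-point step that is known runs a 2.4-fold higher number from compound 2 to compound 3 (0.38 log units; beyond the scatter), and it exchanges the group on the thiocarbonyl carbon rather than the tail that is now in question.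

Compound 4, `CCSC(=S)SCC(=O)c1ccc(OC)cc1`, differs from compound 3 by hydrogen in place of acetamido on a saturated chain carbon, two bonds along the chain from a sulfur. Within the data shown here, no measured pair shows this change directly, so its effect can only be bracketed. Where compound 4 carries an ethylsulfanyl, compound 2 carries an ethoxy, and in this assay compound 2 gives 4640 nM. Compound 3 gives 11100 nM. A modest move toward the lower numbers of compound 1 and compound 2 is expected, so compound 4 is estimated at 6500 nM, within a range of 3000 nM to 14000 nM. This corresponds to an expected step of a 1.7-fold lower number from compound 3 to compound 4 (0.23 log units; within the scatter).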

Compound 4, half-maximal inhibitory concentration: 1960 nM
For compound 4 the middle estimate is 3.3-fold (0.52 log units) above the measured one, outside the stated range (below it).
By their numbers in this assay, from the lowest: compounds 4, 1 and 2 (each within the scatter of the next, the first and the last beyond it); then compound 3.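

Removing the acetamido in this assay gives a 5.7-fold lower number from compound 3 to compound 4 (0.75 log units; beyond the scatter) and so shows that this site, on a saturated chain carbon two bonds along the chain from a sulfur, is sensitive to what it carries, with the unsubstituted ethylsulfanyl at the lower number. Within the data shown here, the step of a 2.4-fold lower number from compound 2 to compound 4 (0.37 log units; beyond the scatter) adds that ethylsulfanyl and ethoxy on the thiocarbonyl carbon are not equivalent in this assay, a difference that could not be read from the earlier compounds. No evidence on hand explains either step.

The compounds shown leave open whether a free amine or a carboxylic acid in place of the acetamido would stay near compound 3 or fall toward compound 4. They also leave open how a longer chain such as propyl or butyl on the sulfur would compare with the ethyl of compound 4.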